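From 1-methylazetidin-3-yl to 1-acetylazetidin-3-yl

The source may hold more compounds than are shown below. What is called first, only, known or untested is meant among the compounds shown, and "the series" means these compounds.

Of the compounds shown here, three sharing one core have been read in a physicochemical assay for solubility, read by spectrophotometry, measured as kinetic solubility, at pH 8, tested at 500 uM; on this read-out lower numbers stand for lower solubility and higher numbers for higher solubility. Compound 1 `Cn1cc(CNC(=O)c2ccncc2Nc2cc(-c3ccc4ccn(C)c4c3)c3nccnc3c2)cn1` gives 127 ug/mL, compound 2 `CC(=O)N1CCCC(NC(=O)c2ccncc2Nc2cc(-c3ccc4ccn(C)c4c3)c3nccnc3c2)C1` gives 212 ug/mL and compound 3 `CN1CC(NC(=O)c2ccncc2Nc2cc(-c3ccc4ccn(C)c4c3)c3nccnc3c2)C1` gives 170 ug/mL. Compound 3 therefore lies within the scatter of both others, and the three values are not separated.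

Compound 4 `CC(=O)N1CC(NC(=O)c2ccncc2Nc2cc(-c3ccc4ccn(C)c4c3)c3nccnc3c2)C1` carries acetyl in place of methyl on an amine nitrogen in a ring, two ring bonds from the ring atom that bears a large group: acetyl in place of methyl on an amine nitrogen in a ring.

Among the measured compounds shown here, no measured pair isolates this exchange. The nearest evidence is a 1.2-fold lower number from compound 2 to compound 3 (0.10 log units; within the scatter), where compound 2 carries an acetyl and compound 3 a methyl, although the ring differs as well. The other two steps, a 1.7-fold higher number from compound 1 to compound 2 (0.22 log units; within the scatter) and a 1.3-fold higher number from compound 1 to compound 3 (0.13 log units; within the scatter), replace the whole group on the amide-type nitrogen and also stay within the scatter.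

No step beyond the scatter is therefore expected in this assay, and any drift would be expected toward the value of compound 2, without confidence in its direction. The expected outcome is a 1.1-fold higher number from compound 3 to compound 4 (0.04 log units; within the scatter). Compound 4 is estimated at 185 ug/mL, with an expected range of 110 ug/mL to 260 ug/mL.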

Compound 4, solubility: 244 ug/mL
Estimate against measurement, compound 4: 1.3-fold (0.12 log units) below, within the range that was stated.
By their numbers in this assay, from the lowest: compounds 1, 3, 2 and 4 (each within the scatter of the next).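

In this assay, the exchange of acetyl for methyl on the amine nitrogen in the four-membered ring can now be read directly with the ring held constant, and a 1.4-fold higher number from compound 3 to compound 4 (0.16 log units; within the scatter) shows no separation at this position. With acetyl kept on the ring nitrogen, the change from 1-acetylpiperidin-3-yl to 1-acetylazetidin-3-yl gives a 1.2-fold higher number from compound 2 to compound 4 (0.06 log units; within the scatter), while the change from (1-methyl-1H-pyrazol-4-yl)methyl to 1-acetylazetidin-3-yl gives a 1.9-fold higher number from compound 1 to compound 4 (0.28 log units; within the scatter), so all the steps among the four compounds remain unresolved. No measurement in hand accounts for any of these small steps.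

Still open, from the compounds shown here alone, is whether any group on this amine nitrogen can produce a step beyond the scatter, which could be tested with a free amine carrying only hydrogen there, a methanesulfonyl group or a short chain ending in a carboxylic acid. Also open, going by these compounds, is whether the acetyl and methyl exchange reads the same way on the larger ring, which would take the 1-methylpiperidin-3-yl group paired with the 1-acetylpiperidin-3-yl group of compound 2.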